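A Pentyl Extension on the Shared Core, Twice Over

The source may report more compounds than this note shows. Statements on the series, on what has been measured and on what is new or still open speak of the compounds shown alone.

Of the compounds shown here, three on one shared core have been tested in a functional assay on MCF7 cells (Homo sapiens) for antiproliferative activity, read by MTT assay, with a stated time of 72 h; a higher number here means a weaker inhibitor, a lower number a stronger inhibitor. Compound 2, `CCCCCCCNC[C@@H]1OC[C@H](N)[C@H]1O`, reaches only the assay limit (the limit of > 128000 nM in this assay, at which 1 of the 3 values shown sits), so its value of > 128000 nM is a boundary rather than a number. Compound 1, `CCCCCCCCCCCCNC[C@@H]1OC[C@H](N)[C@H]1O`, gives 12600 nM in this assay. The change pentyl in place of hydrogen on a saturated chain carbon, seven bonds along the chain from an amine nitrogen thus brought an at least 10-fold lower number from compound 2 to compound 1 (1.00 log units; beyond the scatter). Compound 3, `CCCCCCCCCNC[C@@H]1OC[C@H](N)[C@@H]1O`, gives 12500 nM in this assay; this number and that of compound 1 lie within the usual scatter, so neither can be ranked above the other. The difference between the core of compound 3 and the core of compound 2 is not broken down here.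

Compound 4, `CCCCCCCCCCCCCCNC[C@@H]1OC[C@H](N)[C@@H]1O`, has not yet been measured. It differs from compound 3 by pentyl in place of hydrogen on a saturated chain carbon, nine bonds along the chain from an amine nitrogen. This is the same kind of change as turned compound 2 into compound 1, but the pentyl enters nine bonds along the chain from the amine nitrogen rather than seven. Compound 4 is expected to show a 2.5-fold lower number from compound 3 to compound 4 (0.40 log units; beyond the scatter). A smaller gain than before is estimated, since compound 3 already stands at 12500 nM and compound 1 at 12600 nM. Compound 4 is expected to give about 5000 nM, plausibly between 1500 nM and 15000 nM.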

Compound 4, half-maximal inhibitory concentration: 720 nM
For compound 4 the middle estimate is 6.9-fold (0.84 log units) above the measured one, outside the stated range (below it).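

In this assay, the pentyl extension again goes with a lower number, this time a 17-fold lower number from compound 3 to compound 4 (1.24 log units; beyond the scatter). Set beside the earlier step, the same change points the same way on a second core, and neither step falls within the scatter: the same change on two cores in this assay, an at least 10-fold lower number (1.00 log units; beyond the scatter) from compound 2 to compound 1 and a 17-fold lower number (1.24 log units; beyond the scatter) from compound 3 to compound 4; the limit leaves it open whether they differ. Compound 2 gives > 128000 nM, which is a limit of the assay and not a number, so this comparison cannot say whether the change is worth the same on both cores, and two cores alone make no rule for any further core.

The compounds shown leave open how far this runs: a longer chain might lower the number further or might not, and a chain ending in an amine or a carboxylic acid could behave differently. Also open, going by these compounds, is what the two cores contribute on their own, since every pair compared here differs in its chain.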